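Moving the methyl ring out by one carbon on the amide

The source may report more compounds than this note shows. Statements on the series, on what has been measured and on what is new or still open speak of the compounds shown alone.

Measured compounds:
- compound 1, `COc1cc(-c2nnc(SCC(=O)c3ccc(Cl)cc3)n2N)cc(OC)c1OC`, 13100 nM in a functional assay on HeLa cells (Homo sapiens) for antiproliferative activity, read by MTT assay, with a stated time of 48 h; on this read-out higher numbers stand for weaker inhibition and lower numbers for stronger inhibition
- compound 2, `COc1cc(-c2nnc(SCC(=O)c3ccc(F)c(F)c3)n2N)cc(OC)c1OC`, > 100000 nM in this assay
- compound 3, `COc1cc(-c2nnc(SCC(=O)Nc3ccccc3C)n2N)cc(OC)c1OC`, > 100000 nM in this assay

All three share the same core, varied only at the group on the carbonyl carbon. Compound 1 gives a measured number. For compound 2 the value is a limit of the assay, not a number. For compound 3 likewise the value is a limit and not a number, so compound 3 stands at the weak end of what this assay can report; the limit of > 100000 nM in this assay, at which 2 of the 3 values shown sit, marks that two of the three values sit there. The steps from compound 1 read an at least 7.6-fold higher number from compound 1 to compound 2 (0.88 log units; beyond the scatter) and an at least 7.6-fold higher number from compound 1 to compound 3 (0.88 log units; beyond the scatter), while the step between the two limits, a step that the two limits leave unreadable from compound 2 to compound 3, cannot be sized.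

Compound 4, `COc1cc(-c2nnc(SCC(=O)NCc3ccc(C)cc3)n2N)cc(OC)c1OC`, differs from compound 3 by 4-methylbenzyl in place of 2-methylphenyl on an amide-type nitrogen. For the measured compounds named here, no measured step touches this particular change, and compound 3 itself gives only a limit, so little direction can be read. The step is therefore expected to be a number no higher from compound 3 to compound 4 (the limit leaves the size open), with a further limit the most likely outcome. Compound 4 is estimated at 100000 nM, in a range from 20000 nM to 300000 nM.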

Compound 4, half-maximal inhibitory concentration: > 100000 nM
Compound 4: a limit, no number (the forecaster's own chance of this, stated with the estimate: 70%); the middle value lies on the limit itself.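

Replacing 2-methylphenyl with 4-methylbenzyl on the amide-type nitrogen does not bring a measurable number into this assay: compound 4 gives > 100000 nM, which is a limit of the assay and not a number. The one readable comparison is an at least 7.6-fold higher number from compound 1 to compound 4 (0.88 log units; beyond the scatter), so both groups shown on the amide-type nitrogen, in compound 3 and compound 4, leave the series well on the weak side of the 4-chlorophenyl group of compound 1. The steps to compound 4 from compound 2 and compound 3 join two limits and cannot be read, and the limit now holds most of the series: the limit of > 100000 nM in this assay, at which 3 of the 4 values shown sit.

From the compounds shown here alone, it remains open whether a 4-chlorophenyl group on the amide-type nitrogen would give a number, as it does on the carbonyl carbon. Going by these compounds, it is also open whether a 4-bromophenyl or 4-methoxyphenyl group on the carbonyl carbon would read near compound 1.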